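This account rests on a few compounds, and the source may have more. Where it says the series, first, only, none or still open, it means among the compounds named here.

Measured compounds:
- Compound 1 `O=c1n(Cc2cc3cc(Cl)ccc3n2CCCCO)c2cnccc2n1C1CC1`: > 50000 nM
- Compound 2 `CC(C)(O)CCCn1c(Cn2c(=O)n(C3CC3)c3ccncc32)nc2nc(Cl)ccc21`: > 50000 nM
- Compound 3 `O=c1n(Cc2cc3cc(Cl)ccc3n2CCCC(F)(F)F)c2cnccc2n1C1CC1`: > 50000 nM

In an ADME assay on HeLa cells (Homo sapiens) for cytotoxicity, read by ATP content, with a stated time of 3 days (on this read-out higher numbers stand for lower toxicity in this test and lower numbers for higher toxicity in this test), compound 3 gives > 50000 nM, which is a limit of the test rather than a number. The same holds for the two other measured compounds, so that (the limit of > 50000 nM in this assay, at which 3 of the 3 values shown sit); no compound shown has yet produced a readable number. Compound 4 `CC(C)(O)CCCn1c(Cn2c(=O)n(C3CC3)c3ccncc32)cc2cc(Cl)ccc21` is the next compound. Its change from compound 3 is 1-hydroxy-1-methylethyl in place of trifluoromethyl on a saturated chain carbon, three bonds along the chain from an aromatic nitrogen. Among the compounds with values here, the only measured step that touches this position, a step that the two limits leave unreadable from compound 1 to compound 3, is unreadable, since both of its ends are limits. Compound 2 already carries the 1-hydroxy-1-methylethyl group that enters here, and in this assay compound 2 gives > 50000 nM, again a limit. Within the data shown here, nothing among the measured compounds therefore points to a readable shift: the expected step from compound 3 to compound 4 is a step that the limit leaves unreadable from compound 3 to compound 4, none beyond the scatter. Compound 4 is estimated at 60000 nM, with a range from 30000 nM to 200000 nM, and most likely the assay will again report only a limit.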

Compound 4, half-maximal cytotoxic concentration: > 50000 nM
Compound 4: only a limit was reported (the forecaster's own chance of this, stated with the estimate: 85%); the middle value lies beyond the limit too.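

Compound 4 also ends at a limit rather than a number, so the steps to it from compound 3 and from compound 1 cannot be read: the limit of > 50000 nM in this assay, at which 4 of the 4 values shown sit.

The compounds shown leave open how far past this limit each one lies, and whether any of these chains would give a readable number in this assay.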